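Thiocarbonyl substituent step towards compound 3

A few compounds are considered here, and "the series" means these few. Any claim that something is new, unique, unknown or untested is made for them only; others in the source may bear on it.

Measured in a functional assay on A-375 cells (Homo sapiens) for antiproliferative activity, read by CCK-8 assay, with a stated time of 72 h; a higher number here means a weaker inhibitor, a lower number a stronger inhibitor:
- Compound 1 `Nc1ccccc1NC(=O)c1ccc(CSC(=S)N2CCc3cc(Cl)ccc32)cc1` gives 5280 nM
- Compound 2 `CC1CCCCN1C(=S)SCc1ccc(C(=O)Nc2ccccc2N)cc1` gives 2610 nM

Compound 2 holds the lower of the two numbers. Compound 3 `CCN(Cc1ccncc1)C(=S)SCc1ccc(C(=O)Nc2ccccc2N)cc1` has ethyl((pyridin-4-yl)methyl)amino in place of 2-methylpiperidin-1-yl on a thiocarbonyl carbon. Going by the values given here, only one measured step bears on this place, a 2.0-fold lower number from compound 1 to compound 2 (0.31 log units; beyond the scatter), which is modest and beyond the scatter. Among the compounds with values here, no measured compound carries the entering group, so the direction stays open and no clear shift is expected in this assay. The expected change is a 1.0-fold lower number from compound 2 to compound 3 (0.02 log units; within the scatter). For compound 3 the estimated value is 2500 nM, with an expected range of 900 nM to 7000 nM.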

Compound 3, half-maximal inhibitory concentration: 1940 nM
The estimate for compound 3 lay 1.3-fold (0.11 log units) above the measured number; low and high end bracket the measured number.
By their numbers in this assay, from the lowest: compounds 3 and 2 (each within the scatter of the next); then compound 1.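

In this assay, ethyl((pyridin-4-yl)methyl)amino in place of 2-methylpiperidin-1-yl on a thiocarbonyl carbon gives a 1.3-fold lower number from compound 2 to compound 3 (0.13 log units; within the scatter), so this open question about the entering group resolves to no separable change. In place of 5-chloro-2,3-dihydro-1H-indol-1-yl, the same group gives a 2.7-fold lower number from compound 1 to compound 3 (0.43 log units; beyond the scatter), a modest step in the same direction as the one to 2-methylpiperidin-1-yl. Nothing available accounts for either step.

Open, as far as these compounds go, is whether a morpholine or piperazine at this place would separate from compound 2 and compound 3. A benzyl in place of the (pyridin-4-yl)methyl would test the ring nitrogen.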